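Exchanging One Ring Group on Compound 2

A few compounds are considered here, and "the series" means these few. Any claim that something is new, unique, unknown or untested is made for them only; others in the source may bear on it.

Compound 1 `Nc1n[nH]c2cccc(C#Cc3cccc(C(=O)Nc4cc(C(F)(F)F)cc(C(F)(F)F)c4)c3)c12` reaches only a limit in an ADME assay on L132 cells (Homo sapiens) for inhibition, read by MTT assay, with a stated time of 72 h (on this read-out higher numbers stand for weaker inhibition of growth and lower numbers for stronger inhibition of growth), > 100000 nM. For the measured compounds named here, compound 2 `Cc1cn(-c2cc(NC(=O)c3cccc(C#Cc4cccc5[nH]nc(N)c45)c3)cc(C(F)(F)F)c2)cn1` gives 12900 nM, the only actual number so far. Compound 3 `CN1CCN(Cc2cc(NC(=O)c3cccc(C#Cc4cccc5[nH]nc(N)c45)c3)cc(C(F)(F)F)c2)CC1` carries (4-methylpiperazin-1-yl)methyl in place of 4-methyl-1H-imidazol-1-yl on an aromatic carbon. Going by the values given here, the single measured step, an at least 7.7-fold lower number from compound 1 to compound 2 (0.88 log units; beyond the scatter), introduced the group that now leaves, so it shows that the group can matter but says nothing about the one entering. The expected step, a 1.3-fold lower number from compound 2 to compound 3 (0.11 log units; within the scatter), is therefore estimated to stay within the scatter, with no firm direction. Compound 3 is expected at 10000 nM, with an estimated range of 3000 nM to 40000 nM.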

Compound 3, concentration for 50% growth inhibition: > 100000 nM
Compound 3: only a limit was reported; the forecaster's own chance of this, stated with the estimate: 10%; middle value at least 10-fold (1.00 log units) from the limit.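

In this assay, moving from 4-methyl-1H-imidazol-1-yl to (4-methylpiperazin-1-yl)methyl on the same aromatic carbon gives an at least 7.7-fold higher number from compound 2 to compound 3 (0.88 log units; beyond the scatter), so this exchange weakens growth inhibition beyond the scatter. The value for compound 3 is a limit, not a number: the limit of > 100000 nM in this assay, at which 2 of the 3 values shown sit. The step from compound 1 to compound 3 cannot be read, as both values are limits. For the compounds shown here, compound 2 therefore remains the only compound here with an actual number. From the compounds shown here alone, whether a morpholine ring or a simple amine at this position would also give a number remains open.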